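Same sulfanyl-for-sulfonyl swap tried on a second core

The source may report more compounds than this note shows. Statements on the series, on what has been measured and on what is new or still open speak of the compounds shown alone.

Compound 1 `Cc1ccc(S(=O)(=O)/C(=C/c2ccccc2OCc2ccccc2)C(=O)c2ccc(Br)cc2)cc1` and compound 2 `O=C(/C(=C\c1ccccc1OCc1ccccc1)SCc1ccc(F)cc1)c1ccc(Br)cc1` share one core and differ in a single group: (4-fluorobenzyl)sulfanyl in place of (4-methylphenyl)sulfonyl on a double-bonded chain carbon bound to a carbonyl carbon and a double-bonded chain carbon. In a functional assay on DU-145 cells (Homo sapiens) for inhibition, read by trypan blue exclusion, with a stated time of 96 h (a higher number here means a weaker inhibitor of growth, a lower number a stronger inhibitor of growth), compound 1 gives 1000 nM, and compound 2 gives 1000 nM, so that no change at the digits printed from compound 1 to compound 2 (within the scatter). Compound 3 `CCOc1ccc(/C=C(\C(=O)c2ccc(Cl)cc2)S(=O)(=O)c2ccc(C)cc2)cc1OC` carries the (4-methylphenyl)sulfonyl group of compound 1 on another core; the difference between the two cores is not broken down here. In this assay compound 3 gives 1000 nM, level with compounds 1 and 2. Compound 4 `CCOc1ccc(/C=C(/SCc2ccc(F)cc2)C(=O)c2ccc(Cl)cc2)cc1OC` is not yet measured and stands to compound 3 as compound 2 stands to compound 1: (4-fluorobenzyl)sulfanyl in place of (4-methylphenyl)sulfonyl on a double-bonded chain carbon bound to a carbonyl carbon and a double-bonded chain carbon. The place is described in the same words for both pairs, so this is the same change, made twice among these compounds. Its one measured occurrence left the value where it was, and compound 3 sits at the same level as compound 1, so a flat step is expected again. For compound 4 in this assay the expected value is 1000 nM, most likely between 500 nM and 3000 nM. The expected step is no change at the digits printed from compound 3 to compound 4 (within the scatter), resting on compound 1 and compound 2 having shown no change at the digits printed from compound 1 to compound 2 (within the scatter) and on compound 3 giving 1000 nM.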

Compound 4, concentration for 50% growth inhibition: 1000 nM
Estimate against measurement, compound 4: no gap at the digits printed; the range from low to high includes it.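

In this assay the second occurrence of the change shows no change at the digits printed from compound 3 to compound 4 (within the scatter). Set beside the first occurrence, the change carries from the core of compound 1 to the core of compound 3 with no difference in outcome: the same change on two cores in this assay, no change at the digits printed (within the scatter) from compound 1 to compound 2 and no change at the digits printed (within the scatter) from compound 3 to compound 4, 1.0-fold (0.00 log units) apart, within the scatter of two such steps. This shows that on these two cores, and in this one cell assay, (4-fluorobenzyl)sulfanyl and (4-methylphenyl)sulfonyl cannot be told apart at this place, but it does not show that the same would hold on any further core, and since neither pair moved, the agreement says nothing about whether a step of real size would also carry over.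

The compounds shown leave open what other groups would do on this double-bonded chain carbon, such as an amine, a carboxylic acid or a longer chain. They also leave open whether a plain benzylsulfanyl, without the fluorine, would stay level with compound 2 and compound 4.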